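Adding a Chloro to a Nitrophenyl Spiro-Oxindole

A few compounds are considered here, and "the series" means these few. Any claim that something is new, unique, unknown or untested is made for them only; others in the source may bear on it.

Compound 1 `N#CC1=C(N)Oc2c(c3nc4ccccc4nc3c3ccccc23)C12C(=O)N(Cc1cnnn1-c1cccc(Cl)c1)c1ccccc12`: 43600 nM
Compound 2 `N#CC1=C(N)Oc2c(c3nc4ccccc4nc3c3ccccc23)C12C(=O)N(Cc1cnnn1-c1ccc(Cl)c(Cl)c1)c1ccccc12`: > 50000 nM
Compound 3 `N#CC1=C(N)Oc2c(N)cc3nc4ccccc4nc3c2C12C(=O)N(Cc1cnnn1-c1ccc([N+](=O)[O-])cc1)c1ccccc12`: > 50000 nM

Of the compounds shown here, three sharing one spiro-oxindole core have been measured in a functional assay on MCF7 cells (Homo sapiens) for antiproliferative activity, read by MTT assay, with a stated time of 48 h; a higher number here means a weaker inhibitor, a lower number a stronger inhibitor. Compound 1 gives 43600 nM in this assay. Compound 2 gives > 50000 nM, which is a limit of this assay and not a number. Compound 3 likewise gives > 50000 nM, again a limit of this assay rather than a number, so compound 3 stands at the ceiling of what this assay can report (the limit of > 50000 nM in this assay, at which 2 of the 3 values shown sit).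

Compound 4 `N#CC1=C(N)Oc2c(N)cc3nc4ccccc4nc3c2C12C(=O)N(Cc1cnnn1-c1ccc(Cl)cc1[N+](=O)[O-])c1ccccc12` has not yet been measured. It differs from compound 3 in one place: 4-chloro-2-nitrophenyl in place of 4-nitrophenyl on an aromatic nitrogen.

Going by the values given here, only one measured step bears on this change. Compound 2 differs from compound 1 by one added chloro, and the measured step is an at least 1.1-fold higher number from compound 1 to compound 2 (0.05 log units; that floor lies within the scatter); this gives no sign that adding a chloro strengthens inhibition in this assay. Since compound 3 already sits at the limit, compound 4 is expected to remain at or beyond it, with a step that the limit leaves unreadable from compound 3 to compound 4 in this assay. The estimate for compound 4 in this assay is 65000 nM, expected to fall between 30000 nM and 150000 nM.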

Compound 4, half-maximal inhibitory concentration: > 50000 nM
Compound 4 was reported as a limit (the forecaster's own chance of this, stated with the estimate: 75%); the middle value does not contradict the limit.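

In this assay compound 4 gives > 50000 nM, which is a limit of the assay and not a number. Going by these compounds alone, compound 3 also stands at a limit, so no step from compound 3 to compound 4 can be read: the limit of > 50000 nM in this assay, at which 3 of the 4 values shown sit. The compounds shown leave open whether 4-chloro-2-nitrophenyl in place of 4-nitrophenyl changes inhibition in this assay at all, and in which direction.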